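The source may hold more compounds than are shown below. What is called first, only, known or untested is meant among the compounds shown, and "the series" means these compounds.

Measured in an ADME assay (liver) for pharmacokinetics, with Liver microsome (Rattus norvegicus) as the target, read by LC-MS, using microsomes, tested at 2 uM; on this read-out higher numbers stand for fast clearance and lower numbers for slow clearance:
- compound 1 `O=C(N[C@@H]1CCCC[C@H]1O)c1cnc(Oc2ccccc2)c(-c2ccc(Cl)cc2)c1`: 0.353 mL/min/kg
- compound 2 `O=C(N[C@@H]1CCCC[C@H]1O)c1cnc(OCc2ccccc2)c(-c2ccc(Cl)cc2)c1`: 0.02 mL/min/kg

Of the two measured compounds, compound 2 stands lowest in this assay, and compound 1 is its nearest neighbour. The next structure is compound 3 `O=C(N[C@@H]1CCCC[C@H]1O)c1cnc(OCc2cccnc2)c(-c2ccc(Cl)cc2)c1`, with pyridin-3-yl in place of phenyl on a saturated chain carbon bound to an oxygen on an aromatic ring.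

Within the data shown here, only one measured step bears on this change: an 18-fold lower number from compound 1 to compound 2 (1.25 log units; beyond the scatter), a large step beyond the scatter, for benzyl in place of phenyl on an oxygen on an aromatic ring. Among the measured compounds shown here, it is a different exchange, so it shows only that the number can move widely when this substituent changes. For the measured compounds named here, no measured compound carries pyridin-3-yl. Going by the values given here, compound 2 at 0.02 mL/min/kg is the lowest number so far, so an upward move is the likelier direction, though this is weakly grounded. The expected change is a 2.5-fold higher number from compound 2 to compound 3 (0.40 log units; beyond the scatter), with wide uncertainty. For compound 3 the estimated value is 0.05 mL/min/kg, with an expected range of 0.012 mL/min/kg to 0.2 mL/min/kg.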

Compound 3, clearance: 0.374 mL/min/kg
For compound 3 the middle estimate is 7.5-fold (0.87 log units) below the measured one, and the stated range ends below it.
By their numbers in this assay, from the lowest: compound 2; then compounds 1 and 3 (each within the scatter of the next).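

In this assay, the aromatic ring on the saturated chain carbon bound to an oxygen on an aromatic ring proves to be a sensitive point in its own right: a 19-fold higher number from compound 2 to compound 3 (1.27 log units; beyond the scatter), a large step for pyridin-3-yl in place of phenyl, with the chain carbon left unchanged. The chain carbon alone therefore does not carry the low number of compound 2, since a 1.1-fold higher number from compound 1 to compound 3 (0.03 log units; within the scatter) shows that (pyridin-3-yl)methyl and phenyl on the oxygen cannot be told apart here, and the low number goes with the benzyl group as a whole among these three compounds. No measurement at hand accounts for the size of this step.

It remains open whether the same step would appear with pyridin-2-yl or pyridin-4-yl in place of pyridin-3-yl, so the compounds shown do not tell whether the ring nitrogen's location matters or only its presence. Also open, from the compounds shown here alone, is how the number would respond to a longer chain such as 2-phenylethyl on the oxygen, or to an amine or a carboxylic acid on the benzyl ring.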